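Methyl for methoxy on the benzyl ring of a sulfonylurea

The compounds below may be only part of what the source reports. "The series", "measured", "known", "first", "only" and "open" are said of these compounds alone.

Compound 1 `COc1cc(F)c(CN2C(=O)N(c3ccc(OC)c(OC)c3)S(=O)(=O)c3ccccc32)c(Cl)c1`: 0.1 nM
Compound 2 `COc1cc(N2C(=O)N(Cc3c(F)cc(F)cc3F)c3ccccc3S2(=O)=O)cc(OC)n1`: 1.26 nM

Of the compounds shown here, two sharing a cyclic sulfonylurea core have been measured in an assay on HEK293 cells for displacement of a labelled ligand from Orexin receptor type 2 (Homo sapiens), read by scintillation counting, with a stated time of 90 min; on this read-out higher numbers stand for weaker inhibition and lower numbers for stronger inhibition. Compound 1 gives 0.1 nM, the lower of the two numbers, and compound 2 gives 1.26 nM; the gap between them lies beyond the scatter, but the two structures differ in more than one place, so no single step can be read from them.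

Compound 3 `COc1ccc(N2C(=O)N(Cc3c(F)cc(C)cc3Cl)c3ccccc3S2(=O)=O)cc1OC` keeps everything of compound 1 except for one change: methyl in place of methoxy on an aromatic carbon. A methoxy and a methyl at this position have not been compared elsewhere in this set, so the direction of the step is open. Given that compound 1 stands at 0.1 nM, compound 3 is expected to lose little, with a step from compound 1 to compound 3 in this assay of a 2.0-fold higher number from compound 1 to compound 3 (0.30 log units; within the scatter), at most a modest weakening. Compound 3 is therefore estimated at 0.2 nM, likely between 0.05 nM and 0.8 nM.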

Compound 3, inhibition constant: 0.794 nM
Beside the measured number, compound 3's estimate is 4.0-fold (0.60 log units) below it; the measured number falls inside the stated range.
By their numbers in this assay, from the lowest: compound 1; then compounds 3 and 2 (each within the scatter of the next).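

In this assay, going by these compounds alone, replacing the 2-chloro-6-fluoro-4-methoxybenzyl group with the 2-chloro-6-fluoro-4-methylbenzyl group gives a 7.9-fold higher number from compound 1 to compound 3 (0.90 log units; beyond the scatter) and so provides the first step in this set that can be read at a single place. The position para to a large group therefore responds to this change, and methyl does not serve as an equal replacement for methoxy here. Nothing shown bears on why the number rises.

A single step at one position cannot show whether a hydroxy group, an ethoxy group or an amine at this place would come closer to methoxy or fall further away. Going by these compounds, it also remains open whether the change from methoxy to methyl would give a step of similar size if the rest of the molecule were altered.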